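Benzimidazole series: cytotoxicity on MT4 cells, fluoro to methoxy

The source may report more compounds than this note shows. Statements on the series, on what has been measured and on what is new or still open speak of the compounds shown alone.

Measured so far:
compound 1 `Fc1ccc(-c2nc3cc(C(F)(F)F)ccc3[nH]2)cc1`: 22000 nM
compound 2 `O=[N+]([O-])c1ccc(-c2nc3cc(C(F)(F)F)ccc3n2C2CCCCC2)cc1`: 49000 nM
compound 3 `Cn1c(-c2ccc(N)cc2)nc2cc(C(F)(F)F)ccc21`: 20000 nM

Of the compounds shown here, three on a shared core have been read in an ADME assay on MT4 cells (Homo sapiens) for cytotoxicity, read by MTT assay, with a stated time of 96 h; on this read-out lower numbers stand for higher toxicity in this test and higher numbers for lower toxicity in this test. Compound 1 stands second highest of the three numbers. Compound 3 sits nearest to it, within the scatter, so no order between compound 1 and compound 3 can be claimed. Compound 2 gives the higher number, and its gap to compound 1 lies beyond the scatter; compound 2 is thus the less toxic of that pair in this assay.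

Compound 4 `COc1ccc(-c2nc3cc(C(F)(F)F)ccc3[nH]2)cc1` has not been measured. It differs from compound 1 in one place: methoxy in place of fluoro on an aromatic carbon. Both groups sit on the same aromatic carbon, para to a large group. Among the compounds with values here, no measured pair in the set shows the effect of this kind of exchange, so the direction is open. The step from compound 1 to compound 4 is expected to be small, a 1.1-fold higher number from compound 1 to compound 4 (0.06 log units; within the scatter), with no clear movement beyond the scatter expected. For compound 4 the estimate in this assay is 25000 nM, with a range from 10000 nM to 60000 nM.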

Compound 4, half-maximal cytotoxic concentration: 2000 nM
The estimate for compound 4 lay 13-fold (1.10 log units) above the measured number; the measured number lies below the stated range.
By their numbers in this assay, from the lowest: compound 4; then compounds 3 and 1 (each within the scatter of the next); then compound 2.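

In this assay, methoxy in place of fluoro on an aromatic carbon, para to a large group, gives an 11-fold lower number from compound 1 to compound 4 (1.04 log units; beyond the scatter) and so moves toward higher toxicity in this test. Within the data shown here, this is the first single-place exchange read, and it shows that this position is not silent on this read-out: one substituent change on the core of compound 1 moves the number well beyond the scatter. No measured evidence is available to account for the size of this step.

The compounds shown leave open how a hydroxy group, an ethoxy chain or an amine on the same aromatic carbon would read. They also leave open whether the same exchange would give a step of similar size on the cores of compound 2 and compound 3.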